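Shifting the Thiophene Attachment Point on the Shared Core

The compounds below may be only part of what the source reports. "The series", "measured", "known", "first", "only" and "open" are said of these compounds alone.

Compound 1 `CCOC(=O)C1=C(C)N(C)C(=O)NC1c1cccs1` gives 1% in an assay on membranes from CHO cells for displacement of a labelled ligand from adenosine receptor A1 (Homo sapiens), read by scintillation counting, with a stated time of 60 min, tested at 1 uM; a higher number here means more inhibition at the concentration tested (going by the name of the read-out), a lower number less inhibition.
Compound 2 `CC1=C(C(=O)OCC(C)C)C(c2cccs2)NC(=O)N1C` gives 9% in this assay.

Compound 2 holds the higher of the two numbers, but the step of a number 8 percentage points higher from compound 1 to compound 2 (within the scatter) lies within the scatter, so the two compounds cannot be told apart. Compound 3 `CC1=C(C(=O)OCC(C)C)C(c2ccsc2)NC(=O)N1C` differs from compound 2 by thiophen-3-yl in place of thiophen-2-yl on a saturated ring carbon. Going by the values given here, the only measured step concerns the ester chain, not the thiophene, so no measured step bears on this change. Since both measured numbers are low, compound 3 is expected to stay low as well, with a step of a number 1 percentage points lower from compound 2 to compound 3 (within the scatter) that is not expected to exceed the scatter. Compound 3 is estimated at 8%, ranging from 0% to 20%.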

Compound 3, a percentage reported as inhibition, at one concentration (the size of the read-out at that concentration, not a potency): 8%
Beside the measured number, compound 3's estimate shows no gap at the digits printed; the measured number falls inside the stated range.
By their numbers in this assay, from the lowest: compounds 1, 3 and 2 (each within the scatter of the next).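

In this assay, putting thiophen-3-yl in place of thiophen-2-yl on the saturated ring carbon comes with a number 1 percentage points lower from compound 2 to compound 3 (within the scatter) and so leaves the two compounds indistinguishable. Going by these compounds alone, the earlier step spoke only to the ester chain, whereas this one is the first reading at this ring carbon, and it shows that the thiophene attachment point makes no measurable difference at the concentration tested. Nothing available explains this result. Going by these compounds, it remains open whether a phenyl ring at this ring carbon would give a clearly higher number. On these data alone, a carboxylic acid in place of the ester is equally open.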